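Ester group change from compound 3 to compound 4

The source may report more compounds than this note shows. Statements on the series, on what has been measured and on what is new or still open speak of the compounds shown alone.

Measured values in an assay on membranes from HEK293 cells for displacement of a labelled ligand from adenosine receptor A2b (Homo sapiens), read by scintillation counting, with a stated time of 30 min, tested at 1 uM; on this read-out lower numbers stand for less inhibition and higher numbers for more inhibition at the one concentration tested (going by the name of the read-out):
compound 1 `CC1=C(C(=O)OCc2ccccc2)C(c2ccco2)NC(=S)N1` gives 41%
compound 2 `CC1=C(C(=O)OCC(C)C)C(c2ccsc2)NC(=S)N1` gives 15%
compound 3 `CC1=C(C(=O)OC(C)(C)C)C(c2ccsc2)NC(=S)N1` gives 26%

Compound 3 stands second highest of the three numbers in this assay; its nearest neighbour is compound 2, lower by a margin beyond the scatter, and the furthest is compound 1, higher by a margin beyond the scatter.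

Compound 4 `CC1=C(C(=O)OCc2ccccc2)C(c2ccsc2)NC(=S)N1` is not yet measured in this assay. It differs from compound 3 in one place: benzyl in place of tert-butyl on an oxygen next to a carbonyl group.

Going by the values given here, one measured step touches the same oxygen, a number 11 percentage points higher from compound 2 to compound 3 (beyond the scatter), but it swaps two alkyl groups and does not involve benzyl. Compound 1 carries benzyl at that oxygen yet differs from compound 4 at a second place, so only its value can be set beside that of compound 3; it is the highest number of the three. Taking that as a loose guide, the step of a number 12 percentage points higher from compound 3 to compound 4 (beyond the scatter) is expected to be upward and modest.

Compound 4 is therefore estimated at 38%, within 22% to 55%.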

Compound 4, a percentage reported as inhibition, at one concentration (the size of the read-out at that concentration, not a potency): 10%
Compound 4: the middle estimate sits 28 percentage points above what was measured; the measured number lies below the stated range.
By their numbers in this assay, from the lowest: compounds 4 and 2 (each within the scatter of the next); then compound 3; then compound 1.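

In this assay the change to benzyl on an oxygen next to a carbonyl group gives a number 16 percentage points lower from compound 3 to compound 4 (beyond the scatter) with thiophen-3-yl held constant, so tert-butyl keeps the higher number at this oxygen. Phenyl in place of isopropyl on a saturated chain carbon bound to that oxygen gives a number 5 percentage points lower from compound 2 to compound 4 (within the scatter) and separates nothing, which leaves tert-butyl alone above isobutyl and benzyl among the thiophen-3-yl compounds. Thiophen-3-yl in place of furan-2-yl on a saturated ring carbon gives a number 31 percentage points lower from compound 1 to compound 4 (beyond the scatter) with benzyl held constant, so the high number of compound 1 goes with furan-2-yl and not with benzyl alone.

On these data alone, whether tert-butyl also outdoes benzyl with furan-2-yl on the ring carbon stays open, as does the outcome of a longer chain on this oxygen or a carboxylic acid in place of the ester. No measured evidence accounts for any of these steps.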